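The compounds below may be only part of what the source reports. "The series", "measured", "known", "first", "only" and "open" are said of these compounds alone.

Measured in a functional assay on BXPC-3 cells (Homo sapiens) for antiproliferative activity, read by MTT assay, with a stated time of 24 h; on this read-out lower numbers stand for stronger inhibition and higher numbers for weaker inhibition:
- Compound 1 `CCn1c(C(=O)N[C@@H](CC(=O)OC)C(=O)OC)ccc1C(CC)(CC)c1ccc(OCS(=O)(=O)c2ccccc2)c(C)c1`: > 50000 nM
- Compound 2 `CCn1c(C(=O)NCCN)ccc1C(CC)(CC)c1ccc(OCS(=O)(=O)c2ccccc2)c(C)c1`: 6430 nM
- Compound 3 `CCn1c(C(=O)N[C@@H](C)CO)ccc1C(CC)(CC)c1ccc(OCS(=O)(=O)c2ccccc2)c(C)c1`: 15300 nM

Compound 1 gives only a limit of this assay, > 50000 nM. Of the two actual numbers, compound 3 has the higher at 15300 nM, and its nearest neighbour is compound 2 at 6430 nM.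

Compound 4 `CCn1c(C(=O)NCCO)ccc1C(CC)(CC)c1ccc(OCS(=O)(=O)c2ccccc2)c(C)c1` differs from compound 3 by a single change, (hydrogen in place of methyl on a saturated chain carbon bound to an amide-type nitrogen and a saturated chain carbon), which turns 1-(hydroxymethyl)ethyl into 2-hydroxyethyl. Going by the values given here, no measured step isolates this methyl. Among the compounds with values here, the only guidance comes from exchanges of the whole amide substituent: a 2.4-fold higher number from compound 2 to compound 3 (0.38 log units; beyond the scatter), an at least 3.2-fold lower number from compound 1 to compound 3 (0.51 log units; beyond the scatter) and an at least 7.7-fold lower number from compound 1 to compound 2 (0.89 log units; beyond the scatter). The last two start from a limit, so the exchange a 2.4-fold higher number from compound 2 to compound 3 (0.38 log units; beyond the scatter) is the only one with a defined size. Since that modest step involved a larger exchange than this one, only a small shift is expected in this assay, with no clear direction and probably none beyond the scatter. The expected step is a 1.3-fold lower number from compound 3 to compound 4 (0.11 log units; within the scatter). For compound 4 the estimated value is 12000 nM, with an expected range of 5500 nM to 27000 nM.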

Compound 4, half-maximal inhibitory concentration: 19900 nM
Beside the measured number, compound 4's estimate is 1.7-fold (0.22 log units) below it, and the stated range covers the measured number.
By their numbers in this assay, from the lowest: compound 2; then compounds 3 and 4 (each within the scatter of the next). At a limit, above all of these: compound 1.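

In this assay, taking the methyl away from the saturated chain carbon bound to an amide-type nitrogen and a saturated chain carbon gives a 1.3-fold higher number from compound 3 to compound 4 (0.11 log units; within the scatter), so this assay does not separate 1-(hydroxymethyl)ethyl from 2-hydroxyethyl. The chain end can now be read on its own, without the methyl also changing, as hydroxy in place of amino gives a 3.1-fold higher number from compound 2 to compound 4 (0.49 log units; beyond the scatter). Replacing 1,2-bis(methoxycarbonyl)ethyl with 2-hydroxyethyl gives an at least 2.5-fold lower number from compound 1 to compound 4 (0.40 log units; beyond the scatter), which is a bound only, since compound 1 sits at a limit: the limit of > 50000 nM in this assay, at which 1 of the 4 values shown sits.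

The compounds shown leave open whether the lower number seen with the amino group would persist in a longer chain or with a dimethylamino group at the chain end. They also do not show how a carboxylic acid at that chain end would read, or whether a methyl on the chain of the amino compound would matter any more than it does here.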